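The source may report more compounds than this note shows. Statements on the series, on what has been measured and on what is new or still open speak of the compounds shown alone.

Compound 1 `C[C@H](NC(=O)Nc1ccccc1Br)c1ccccc1` carries a bromo group on one of its aromatic rings. In an ADME assay on the whole organism with Oryza sativa as the target, tested at 0.1 uM (a lower number here means a stronger effect, a higher number a weaker effect of the compound at the concentration tested), compound 1 gives 101%. Compound 2 `C[C@@H](NC(=O)Nc1cccc(Br)c1)c1ccccc1` is built from the same atoms as compound 1, joined differently; the difference between the two cores is not broken down here. In this assay compound 2 gives 100%. Compound 3 `C[C@H](NC(=O)Nc1ccccc1I)c1ccccc1` differs from compound 1 in one place only, by iodo in place of bromo on an aromatic carbon. In this assay compound 3 gives 99%. The step of a number 2 percentage points lower from compound 1 to compound 3 (within the scatter), and the three measured numbers all lie within the usual scatter of one another, so no order among them can be read.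

Compound 4 `C[C@@H](NC(=O)Nc1cccc(I)c1)c1ccccc1` has not yet been measured. It differs from compound 2 by iodo in place of bromo on an aromatic carbon. This is the same kind of change as that from compound 1 to compound 3, but not the same: in compound 3 the entering iodo sits ortho to a large group, whereas in compound 4 it sits meta to a large group.

For compound 4 the step of no change at the digits printed from compound 2 to compound 4 (within the scatter) is expected, because a number 2 percentage points lower from compound 1 to compound 3 (within the scatter) stayed within the scatter when the same exchange was made on the core of compound 1. On that basis compound 4 is estimated to give 100% in this assay, with an expected range from 92% to 108%.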

Compound 4, a percentage reported as activity, at one concentration (the size of the read-out at that concentration, not a potency): 81%
Compound 4: middle estimate off by 19 percentage points, on the high side; the whole stated range lies above it.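

In this assay, iodo in place of bromo on an aromatic carbon gives a number 19 percentage points lower from compound 2 to compound 4 (beyond the scatter), and this step does not match the one seen on the other core: the same change on two cores in this assay, a number 2 percentage points lower (within the scatter) from compound 1 to compound 3 and a number 19 percentage points lower (beyond the scatter) from compound 2 to compound 4, 17 percentage points apart, beyond the scatter of two such steps. This shows that, among these compounds, the size of the exchange cannot simply be carried from one core to another, so the small step on the core of compound 1 was a poor guide to the step on the core of compound 2. It does not show which difference between the two cores matters, or whether the lower number for compound 4 is a general feature of iodo meta to a large group, since the comparison rests on a single pair of steps and offers no measured explanation.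

The compounds shown leave open how a smaller halogen such as chloro or fluoro, or a methyl or methoxy group, would behave in the place that iodo occupies in compound 4. They also leave open whether an amine or a carboxylic acid at that place would give a number closer to that of compound 2 or to that of compound 4.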